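From 3-methylphenyl to 2-methylphenyl: compound 3 to compound 4

The source may report more compounds than this note shows. Statements on the series, on what has been measured and on what is new or still open speak of the compounds shown alone.

In a functional assay on ileum (Cavia porcellus) for antagonist activity (on this read-out lower numbers stand for stronger inhibition and higher numbers for weaker inhibition), compound 3 `Cc1cccc(OCCCOc2ccc3c(O)c([N+](=O)[O-])c(=O)oc3c2)c1` gives 4400 nM and compound 1 `Cc1ccc(CCCCOc2ccc3c(O)c([N+](=O)[O-])c(=O)oc3c2)cc1` gives 2500 nM, two values within the scatter of each other. Compound 2 `O=C(O)c1ccc(OCCCOc2ccc3c(O)c([N+](=O)[O-])c(=O)oc3c2)cc1` reads > 20000 nM, which is a limit of this assay and not a number.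

Compound 4 `Cc1ccccc1OCCCOc1ccc2c(O)c([N+](=O)[O-])c(=O)oc2c1` has the same atoms as compound 3, joined differently, with 2-methylphenyl in place of 3-methylphenyl on an oxygen on a saturated carbon.

The closest guide is a 1.8-fold higher number from compound 1 to compound 3 (0.25 log units; within the scatter), where 3-methylphenoxy replaced 4-methylbenzyl. The other measured change, an at least 4.5-fold lower number from compound 2 to compound 3 (0.65 log units; beyond the scatter), went beyond the scatter, but it replaced 4-carboxyphenyl, a group that plays no part in the new change. A methyl group that merely moves is therefore expected to do little in this assay, with no direction favoured and nothing beyond the scatter: the estimated step is a 1.1-fold lower number from compound 3 to compound 4 (0.04 log units; within the scatter). For compound 4 the expected value is 4000 nM, within an estimated range of 1500 nM to 11000 nM.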

Compound 4, half-maximal inhibitory concentration: 590 nM
For compound 4 the middle estimate is 6.8-fold (0.83 log units) above the measured one, and the stated range ends above it.
By their numbers in this assay, from the lowest: compound 4; then compounds 1 and 3 (each within the scatter of the next). At a limit, above all of these: compound 2.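

Where the methyl group sits on the ring matters in this assay: 2-methylphenyl in place of 3-methylphenyl, with the same atoms joined differently, gives a 7.5-fold lower number from compound 3 to compound 4 (0.87 log units; beyond the scatter). The 2-methylphenoxy group also separates from 4-methylbenzyl, which 3-methylphenoxy did not do, with a 4.2-fold lower number from compound 1 to compound 4 (0.63 log units; beyond the scatter). The widest step, an at least 33-fold lower number from compound 2 to compound 4 (1.53 log units; beyond the scatter), starts from a limit and not a number: the limit of > 20000 nM in this assay, at which 1 of the 4 values shown sits.

The compounds shown do not tell whether this gain needs a methyl group at all, since an unsubstituted phenyl, a 2-chlorophenyl and a 2-methoxyphenyl group are not among them. They also leave open why the place of the methyl group matters, and whether 2-methylphenoxy would hold its advantage on a longer chain.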